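This account rests on a few compounds, and the source may have more. Where it says the series, first, only, none or still open, it means among the compounds named here.

Compound 2 `CC(C(=O)N1Cc2ccccc2C1)N1CCN(S(=O)(=O)c2ccc(C(C)(C)C)cc2)CC1` is the starting point of this step. In an ADME assay on HepG2 cells (Homo sapiens) for inhibition, with a stated time of 48 h (on this read-out lower numbers stand for an effect already at smaller amounts and higher numbers for an effect only at larger amounts of compound), compound 2 gives > 40000 nM, which is a limit of the assay and not a number. Compound 1 `CC(C(=O)N1C[C@H]2CCC[C@H]2C1)N1CCN(S(=O)(=O)c2ccc(C(C)(C)C)cc2)CC1` differs from it only in the group on the carbonyl carbon. In this assay compound 1 gives > 40000 nM, again a limit and not a number. The step that the two limits leave unreadable from compound 1 to compound 2 therefore cannot be read in either direction, since (the limit of > 40000 nM in this assay, at which 2 of the 2 values shown sit). Compound 3 `CC(C(=O)N1CCc2ccccc2C1C)N1CCN(S(=O)(=O)c2ccc(C(C)(C)C)cc2)CC1` departs from compound 2 by a group of 11 heavy atoms (10 carbon, 1 nitrogen; one six-membered non-aromatic ring with 1 hetero atom, one six-membered aromatic ring of carbon only) in place of a group of 9 heavy atoms (8 carbon, 1 nitrogen; one five-membered non-aromatic ring with 1 hetero atom, one six-membered aromatic ring of carbon only), on a carbonyl carbon. Within the data shown here, the single measured step, from compound 1 to compound 2, also exchanges the group on the carbonyl carbon, and its size is unreadable; it thus offers no direction for the change to compound 3. The expected step of a number no higher from compound 2 to compound 3 (the limit leaves the size open) is accordingly none beyond the scatter, with the result most likely resting once more at the limit. Compound 3 is therefore estimated at 40000 nM, within a range from 15000 nM to 100000 nM, with a considerable chance that only a limit is reported.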

Compound 3, half-maximal effective concentration: 28000 nM
Compound 3: the middle estimate sits 1.4-fold (0.15 log units) above what was measured, within the range that was stated.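

In this assay compound 3, which carries 1-methyl-1,2,3,4-tetrahydroisoquinolin-2-yl on the carbonyl carbon, gives 28000 nM, the first value among the compounds shown that is a number and not a limit. Among these compounds, an exchange of the group at this place can therefore be given a size for the first time, though only as a floor, as an at least 1.4-fold lower number from compound 2 to compound 3 (0.15 log units; that floor lies within the scatter) and as an at least 1.4-fold lower number from compound 1 to compound 3 (0.15 log units; that floor lies within the scatter). Neither step shows on its own a change beyond the scatter, and the two other compounds remain at a limit of the assay: the limit of > 40000 nM in this assay, at which 2 of the 3 values shown sit.

The true size of both steps stays open, as the compounds shown give no number for compound 1 or compound 2, so it cannot be said how far compound 3 truly stands from either. From the compounds shown here alone, it is also open what in 1-methyl-1,2,3,4-tetrahydroisoquinolin-2-yl goes with the measured number, a question that 1,2,3,4-tetrahydroisoquinolin-2-yl without the methyl, or a piperidin-1-yl or morpholin-4-yl on the same carbonyl carbon, would bear on.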